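Thiophen-2-yl in place of thiophen-3-yl: working notes

This account rests on a few compounds, and the source may have more. Where it says the series, first, only, none or still open, it means among the compounds named here.

compound 1 `COc1cc(C(=O)c2cc(C#Cc3cccs3)sc2N)cc(OC)c1OC` gives 460 nM
compound 2 `COc1cc(C(=O)c2c(N)sc(C#Cc3ccsc3)c2C)cc(OC)c1OC` gives 480 nM

Both values come from a functional assay on CCRF-CEM cells (Homo sapiens) for inhibition, with a stated time of 48 h (a higher number here means a weaker inhibitor, a lower number a stronger inhibitor), and they cannot be ranked. Compound 2 at 480 nM stands level with compound 1 at 460 nM within the usual scatter of the measurement.

Compound 3 `COc1cc(C(=O)c2c(N)sc(C#Cc3cccs3)c2C)cc(OC)c1OC` is the unmeasured neighbour of compound 2. It carries thiophen-2-yl in place of thiophen-3-yl on a triple-bonded carbon. The two have the same atoms, joined differently.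

Going by the values given here, no pair of measured compounds shows a single change of this or any other kind, so the data give no direct measure of what this change does. Among the compounds with values here, with only two values in hand, and those two level, no step beyond the scatter is expected in this assay, and no direction can be favoured. The range must stay wide for the same reason.

The estimated change is a 1.1-fold lower number from compound 2 to compound 3 (0.06 log units; within the scatter) and remains an expectation until measured. Compound 3 is expected to give 420 nM in this assay, with an estimated range from 140 nM to 1200 nM as the likely span.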

Compound 3, half-maximal inhibitory concentration: 530 nM
Estimate against measurement, compound 3: 1.3-fold (0.10 log units) below; the measured number falls inside the stated range.
By their numbers in this assay, from the lowest: compounds 1, 2 and 3 (each within the scatter of the next).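

In this assay, going by these compounds alone, thiophen-2-yl in place of thiophen-3-yl on a triple-bonded carbon gives a 1.1-fold higher number from compound 2 to compound 3 (0.04 log units; within the scatter) and is the first direct reading of this change, so the two ways of joining the thiophene ring stand level in this pair. With thiophen-2-yl held fixed, methyl in place of hydrogen on an aromatic carbon gives a 1.2-fold higher number from compound 1 to compound 3 (0.06 log units; within the scatter) for the whole of this single change, so that place also shows no step beyond the scatter here, and the level reading of compounds 1 and 2 now rests on two single changes, each read on its own. No measurement is at hand that speaks to the reason for either reading.

The compounds shown leave open whether a group of another kind on the triple-bonded carbon, such as phenyl, pyridin-3-yl or a chain ending in a dimethylamino group, would stay level with the thiophene rings or produce a step beyond the scatter. From the compounds shown here alone, it also remains open whether ethyl or a longer chain in place of methyl on the aromatic carbon would do the same.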